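A New Aryl Group on the Aromatic Nitrogen

The source may hold more compounds than are shown below. What is called first, only, known or untested is meant among the compounds shown, and "the series" means these compounds.

Going by the values given here, compound 3 `CCOC(=O)C1=Cc2ccccc2OC1(OCc1cn(-c2ccc(F)c(Cl)c2)nn1)C(F)(F)F` gives 22700 nM in a functional assay on HeLa cells (Homo sapiens) for inhibition, read by MTT assay, with a stated time of 24 h (on this read-out lower numbers stand for stronger inhibition and higher numbers for weaker inhibition), the lowest of the three numbers measured so far; compound 2 `CCOC(=O)C1=Cc2ccccc2OC1(OCc1cn(CC(=O)Nc2ccccc2F)nn1)C(F)(F)F` gives 49900 nM and compound 1 `CCOC(=O)C1=Cc2ccccc2OC1(OCc1cn(CC(=O)Nc2ccc(C)cc2)nn1)C(F)(F)F` gives 67400 nM. Compound 4 `CCOC(=O)C1=Cc2ccccc2OC1(OCc1cn(-c2cccc(C(F)(F)F)c2)nn1)C(F)(F)F` differs from compound 3 in one place: 3-(trifluoromethyl)phenyl in place of 3-chloro-4-fluorophenyl on an aromatic nitrogen. Among the compounds with values here, the measured steps of a 3.0-fold lower number from compound 1 to compound 3 (0.47 log units; beyond the scatter) and a 2.2-fold lower number from compound 2 to compound 3 (0.34 log units; beyond the scatter) each replaced a larger group with an aryl ring on the aromatic nitrogen; no measured step compares one aryl ring with another, so they bear only loosely on this change. Within the data shown here, with no direct precedent, the expected step from compound 3 to compound 4 is none beyond the scatter, a 1.0-fold lower number from compound 3 to compound 4 (0.01 log units; within the scatter). Compound 4 is estimated at 22000 nM, with a range from 8000 nM to 60000 nM.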

Compound 4, half-maximal inhibitory concentration: > 150000 nM
Compound 4 gave a limit, no number (the forecaster's own chance of this, stated with the estimate: 10%); middle value at least 6.8-fold (0.83 log units) away from the limit.
By their numbers in this assay, from the lowest: compound 3; then compounds 2 and 1 (each within the scatter of the next). At a limit, above all of these: compound 4.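

In this assay compound 4 gives a limit, not a number: the limit of > 150000 nM in this assay, at which 1 of the 4 values shown sits. Going by these compounds alone, this is the first comparison of one aryl ring with another on the aromatic nitrogen, and it shows an at least 6.6-fold higher number from compound 3 to compound 4 (0.82 log units; beyond the scatter), so an aryl ring there does not by itself give the lowest number. The earlier carbamoyl groups also compare favourably with 3-(trifluoromethyl)phenyl, with an at least 3.0-fold higher number from compound 2 to compound 4 (0.47 log units; beyond the scatter) and an at least 2.2-fold higher number from compound 1 to compound 4 (0.34 log units; beyond the scatter).

The two aryl rings differ in more than one substituent, so the chlorine, the ring fluorine and the trifluoromethyl cannot be separated. Going by these compounds, how a phenyl ring carrying an amine or a methoxy group would read also remains open.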